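Lengthening an Amine-Bearing Chain in Compound 2

The compounds below may be only part of what the source reports. "The series", "measured", "known", "first", "only" and "open" are said of these compounds alone.

Of the compounds shown here, three have been tested in a functional assay on Umbilical vein for antagonist activity at B1 bradykinin receptor (Homo sapiens), using Schild analysis, with a stated time of 30 min; on this read-out lower numbers stand for lower potency and higher numbers for higher potency (the scale is a negative logarithm). Compound 1 `COc1ccc(S(=O)(=O)N(C)CCOCC(=O)N(C)Cc2ccc(C3=NCCN3)cc2)c(C)c1` gives 8.6, compound 3 `CN(Cc1ccc(C2=NCCN2)cc1)C(=O)COCCN(C)S(=O)(=O)c1c(F)cccc1F` gives 7.6, and compound 2 `COc1cc(C)c(S(=O)(=O)N(C)CCOCC(=O)N2CCN(CCN(C)C)CC2)c(C)c1` gives 7.4, the lowest of the three, within the scatter of compound 3 and clearly under compound 1. Among the measured compounds shown here, the only step between compounds that differ in one place is a number 1.00 log units lower from compound 1 to compound 3 (beyond the scatter), which alters the group on the sulfonyl sulfur. Compound 4 `COc1cc(C)c(S(=O)(=O)N(C)CCOCC(=O)N2CCN(CCCN(C)C)CC2)c(C)c1` differs from compound 2 at another position: (dimethylamino)methyl in place of dimethylamino on a saturated chain carbon, two bonds along the chain from an amine nitrogen in a ring. For the measured compounds named here, no measured step touches this part of the molecule, so nothing here points to a change beyond the scatter in this assay. Compound 4 is therefore expected at 7.4, between 6.8 and 8. The expected step is no change at the digits printed from compound 2 to compound 4 (within the scatter).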

Compound 4, negative logarithm of the antagonist equilibrium constant: 7.9
Estimate against measurement, compound 4: 0.50 log units below; measured number inside the range.
By their numbers in this assay, from the lowest: compounds 2, 3 and 4 (each within the scatter of the next, the first and the last beyond it); then compound 1.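

Lengthening the chain, with (dimethylamino)methyl in place of dimethylamino on a saturated chain carbon, gives a number 0.50 log units higher from compound 2 to compound 4 (beyond the scatter) in this assay. Among the compounds shown here, this part of the molecule, untouched by the earlier steps, therefore responds to a small change in chain length. Nothing available explains why the longer chain gives the higher number.

Two chain lengths cannot show a trend, so the compounds shown leave open whether 2-(dimethylamino)ethyl or 3-(dimethylamino)propyl would raise the number further. They also leave open whether the chain's end needs an amine at all, which a carboxylic acid there would test.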